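The source may hold more compounds than are shown below. What is called first, only, known or untested is meant among the compounds shown, and "the series" means these compounds.

Measured in an ADME assay on L6 cells (Rattus norvegicus) for cytotoxicity, read by fluorescence and resazurin assay, with a stated time of 72 h; a higher number here means that more compound is tolerated, a lower number that less compound is tolerated:
- compound 1 `c1ccc(C(c2ccn(-c3ccccc3)c2)n2ccnc2)cc1`: 80800 nM
- compound 2 `Fc1ccc(-n2ccc(C(c3ccccc3)n3ccnc3)c2)cc1`: 104000 nM

Only these two compounds have been measured so far, and their values lie within the scatter of each other. Compound 2, at 104000 nM, therefore cannot be separated from compound 1. The next compound is compound 3 `Fc1ccc(-n2ccc(C(c3ccc(Cl)cc3)n3ccnc3)c2)cc1`, in which phenyl becomes 4-chlorophenyl, with chloro in place of hydrogen on an aromatic carbon.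

Going by the values given here, one measured step bears on this change, and only loosely: a 1.3-fold higher number from compound 1 to compound 2 (0.11 log units; within the scatter). That step also replaces hydrogen on an aromatic carbon, but it brings in fluoro, not chloro. Among the compounds with values here, no measured step shows what chloro does here. Within the data shown here, the one available step gives no reason to expect a large shift, so only a modest move is anticipated, leaning cautiously towards a lower number and possibly staying within the scatter. The estimated change is a 1.7-fold lower number from compound 2 to compound 3 (0.24 log units; within the scatter). For compound 3 the expected value in this assay is 60000 nM, with an estimated range of 20000 nM to 125000 nM.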

Compound 3, half-maximal cytotoxic concentration: 47500 nM
Beside the measured number, compound 3's estimate is 1.3-fold (0.10 log units) above it; the range from low to high includes it.
By their numbers in this assay, from the lowest: compounds 3, 1 and 2 (each within the scatter of the next, the first and the last beyond it).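

Going by these compounds alone, the change from phenyl to 4-chlorophenyl gives the first step in this assay that lies beyond the scatter (a 2.2-fold lower number from compound 2 to compound 3 (0.34 log units; beyond the scatter)), though it remains modest, and it shows that chloro on this aromatic carbon, para to a large group, registers in the read-out with less compound tolerated. The earlier step (a 1.3-fold higher number from compound 1 to compound 2 (0.11 log units; within the scatter)) put fluoro at a different place on the shared core and stayed within the scatter, so it could not show whether any substitution on an aromatic carbon would matter in this series. The two steps differ in both the group and its place, so they cannot be read as a trend, and nothing in hand explains why chloro has this effect.

Going by these compounds, it remains open whether this modest fall belongs to chloro itself or would also follow from another group at the same place, such as methoxy, trifluoromethyl or an amine. On these data alone, it is equally open whether chloro would give a step of similar size on the core of compound 1, without the fluoro, or at another carbon of the same ring.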